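Bromo for chloro: 3-chlorophenyl to 3-bromophenyl

The compounds below may be only part of what the source reports. "The series", "measured", "known", "first", "only" and "open" are said of these compounds alone.

In a functional assay on MCF7 cells (Homo sapiens) for inhibition, read by MTT assay, with a stated time of 72 h (a higher number here means a weaker inhibitor, a lower number a stronger inhibitor), compound 1 `COc1cccc(NC(=O)C2CCN(C/C=C/c3ccccc3)CC2)c1` gives 42700 nM, compound 2 `O=C(Nc1cccc(C(F)(F)F)c1)C1CCN(C/C=C/c2ccccc2)CC1` gives 16100 nM and compound 3 `O=C(Nc1cccc(Cl)c1)C1CCN(C/C=C/c2ccccc2)CC1` gives 16100 nM. Compound 3 is thus level with compound 2, together the lowest of the three numbers. Compound 4 `O=C(Nc1cccc(Br)c1)C1CCN(C/C=C/c2ccccc2)CC1` differs from compound 3 by one change: bromo in place of chloro on an aromatic carbon. The closest measured precedent among the aromatic substituents is no change at the digits printed from compound 2 to compound 3 (within the scatter), which lies within the scatter. The two steps away from methoxy, a 2.7-fold lower number from compound 1 to compound 2 (0.42 log units; beyond the scatter) and a 2.7-fold lower number from compound 1 to compound 3 (0.42 log units; beyond the scatter), are modest and start from a different group. The estimated step, a 1.1-fold lower number from compound 3 to compound 4 (0.03 log units; within the scatter), is therefore expected to stay within the scatter, with no direction favoured. For compound 4 the estimated value is 15000 nM, with an expected range of 8000 nM to 28000 nM.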

Compound 4, half-maximal inhibitory concentration: 11500 nM
For compound 4 the middle estimate is 1.3-fold (0.12 log units) above the measured one, within the range that was stated.
By their numbers in this assay, from the lowest: compounds 4, 2 and 3 (each within the scatter of the next); then compound 1.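

In this assay, bromo joins chloro and trifluoromethyl as a third group at this position that reads level: a 1.4-fold lower number from compound 3 to compound 4 (0.15 log units; within the scatter) and a 1.4-fold lower number from compound 2 to compound 4 (0.15 log units; within the scatter). Methoxy alone stands apart, and a 3.7-fold lower number from compound 1 to compound 4 (0.57 log units; beyond the scatter) is the widest step in the set so far, though still modest. Nothing at hand bears on why these three groups read alike. Open, as far as these compounds go, is how an amine or a carboxylic acid would read on this aromatic carbon. Also open, from the compounds shown here alone, is whether fluoro or iodo would stay level with chloro and bromo.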